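Turning a Methyl into an Ethyl on Compound 1

The compounds below may be only part of what the source reports. "The series", "measured", "known", "first", "only" and "open" are said of these compounds alone.

In a functional assay on HMEC-1 cells (Homo sapiens) for inhibition, read by cell counting, with a stated time of 4 days (a lower number here means a stronger inhibitor, a higher number a weaker inhibitor), compound 1 (`COc1ccc(N(C)c2nc(C)nc3c2nc(C)n3C)cc1`) gives 7300 nM. Among the measured compounds shown here, the only other measured compound, compound 2 (`COc1ccc(N(C)c2nc(C)nc3[nH]c(C)nc23)cc1`), gives 7100 nM, so compound 1 stands level with it, and the two values lie within the scatter of each other. For the measured compounds named here, the single measured step, hydrogen in place of methyl on an aromatic nitrogen, is a 1.0-fold lower number from compound 1 to compound 2 (0.01 log units; within the scatter).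

Compound 3 (`CCN(c1ccc(OC)cc1)c1nc(C)nc2c1nc(C)n2C`) changes compound 1 at a different place: methyl in place of hydrogen on a saturated chain carbon bound to a nitrogen on an aromatic ring. This is methyl in place of hydrogen on a saturated chain carbon bound to a nitrogen on an aromatic ring, so a methyl becomes an ethyl. Going by the values given here, no measured step tests this place, which makes the step to compound 2 only a loose guide. Still, compound 2 at 7100 nM shows one small change elsewhere on the molecule that moved nothing beyond the scatter. In this assay, then, no step beyond the scatter is expected, in either direction. The expected size is a 1.2-fold higher number from compound 1 to compound 3 (0.07 log units; within the scatter). For compound 3 the estimated value is 8500 nM. The expected range is wide, running from 2500 nM to 30000 nM.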

Compound 3, half-maximal inhibitory concentration: 8800 nM
Compound 3: middle estimate off by 1.0-fold (0.02 log units), on the low side, within the range that was stated.
By their numbers in this assay, from the lowest: compounds 2, 1 and 3 (each within the scatter of the next).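

Turning the methyl into an ethyl, on a saturated chain carbon bound to a nitrogen on an aromatic ring, is a step of a 1.2-fold higher number from compound 1 to compound 3 (0.08 log units; within the scatter) in this assay. Among the compounds shown here, the earlier pair tested only the aromatic nitrogen, so this is the first reading at this position, and it adds a second place on the molecule where one small change leaves the number within the scatter, with the single added carbon not separating compound 3 from compound 1. Nothing available explains why the numbers stay so close, and a step this small offers little to explain.

As far as these compounds go, a single ethyl says little about how much room this position allows, so it remains open whether a longer chain such as butyl, or a chain carrying an amine or a carboxylic acid, would stay within the scatter of compound 1 or move the number beyond it. The methoxy group and the other methyl groups on the shared core also remain open, since no step shown here tests any of them.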